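Dechlorination step across two linker variants

A few compounds are considered here, and "the series" means these few. Any claim that something is new, unique, unknown or untested is made for them only; others in the source may bear on it.

In an assay on isolated protein for inhibition of Dihydrofolate reductase (Mus musculus) (a higher number here means a more potent compound, by a factor of ten per unit of this negative logarithm, a lower number a less potent compound), compound 1 `CC1(C)N=C(N)N=C(N)N1c1cc(Cl)c(OCC(=O)Nc2ccc(S(=O)(=O)F)cc2)c(Cl)c1` gives 7.74. Compound 3 `CC1(C)N=C(N)N=C(N)N1c1ccc(OCC(=O)Nc2ccc(S(=O)(=O)F)cc2)c(Cl)c1` differs from compound 1 by hydrogen in place of chloro on an aromatic carbon, and in this assay compound 3 gives 7.43; the step is a number 0.31 log units lower from compound 1 to compound 3 (beyond the scatter). Compound 2 `CC1(C)N=C(N)N=C(N)N1c1ccc(Cl)c(OCCOc2ccc(S(=O)(=O)F)cc2)c1` carries a different core, and the difference between the two cores is not broken down here. In this assay compound 2 gives 7.27, which lies within the scatter of compound 3 and beyond it against compound 1. Compound 4 `CC1(C)N=C(N)N=C(N)N1c1cccc(OCCOc2ccc(S(=O)(=O)F)cc2)c1` differs from compound 2 by hydrogen in place of chloro on an aromatic carbon. This is the same kind of change as from compound 1 to compound 3, though there the place is meta to a chloro group and meta to a large group, while here it is para to a large group. A step of a number 0.30 log units lower from compound 2 to compound 4 (within the scatter) is expected, resting on the earlier step of a number 0.31 log units lower from compound 1 to compound 3 (beyond the scatter). Compound 4 is expected at 6.97, estimated between 6.55 and 7.4.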

Compound 4, logarithm of the reciprocal of the active concentration, log(1/C): 7.82
Estimate against measurement, compound 4: 0.85 log units below; measured number above the stated range.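

Hydrogen in place of chloro on an aromatic carbon gives a number 0.55 log units higher from compound 2 to compound 4 (beyond the scatter) in this assay. Set beside the earlier step, the same change does not carry over from one core to the other in either size or direction: the same change on two cores in this assay, a number 0.31 log units lower (beyond the scatter) from compound 1 to compound 3 and a number 0.55 log units higher (beyond the scatter) from compound 2 to compound 4, 0.86 log units apart, beyond the scatter of two such steps. Among these compounds, with only two pairs, which differ in both the core and the place of the change on the ring, the data do not separate these two differences or show how the change would behave on a third core.

On these data alone, whether fluoro or methyl in place of the chloro would split the same way remains open. So does whether a longer chain as the linker would alter the outcome.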